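This account rests on a few compounds, and the source may have more. Where it says the series, first, only, none or still open, it means among the compounds named here.

Measured so far in an assay on CHO-K1 cells for inhibition of 11-beta-hydroxysteroid dehydrogenase type 2 (Homo sapiens), read by scintillation proximity assay; on this read-out lower numbers stand for stronger inhibition and higher numbers for weaker inhibition:
compound 1, `CCS(=O)(=O)CCC12CCC(c3nnc(-c4ccccc4Br)n3C)(CC1)CC2`: > 4000 nM
compound 2, `CC(C)S(=O)(=O)CCC12CCC(c3nnc(-c4ccccc4C(F)(F)F)n3C)(CC1)CC2`: > 4000 nM

Compound 2 stands at a limit of this assay, not at a number. All the evidence here is the limit of > 4000 nM in this assay, at which 2 of the 2 values shown sit, so no ordering among the measured compounds can be drawn. Compound 3, `CC(F)CCCC12CCC(c3nnc(-c4ccccc4C(F)(F)F)n3C)(CC1)CC2`, differs from compound 2 by 2-fluoropropyl in place of isopropylsulfonyl on a saturated chain carbon, two bonds along the chain from a saturated ring carbon. Among the compounds with values here, no measured step covers this change, and no direction can be read from the values shown; the expected step is a step that the limit leaves unreadable from compound 2 to compound 3, nothing beyond the scatter. Compound 3 is expected to give about 5000 nM in this assay, between 1500 nM and 20000 nM.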

Compound 3, half-maximal inhibitory concentration: 1300 nM
Compound 3: the middle estimate sits 3.8-fold (0.59 log units) above what was measured, outside the stated range (below it).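

In this assay, within the data shown here, this place on the chain is the first to yield a number rather than a limit: 2-fluoropropyl in place of isopropylsulfonyl gives an at least 3.0-fold lower number from compound 2 to compound 3 (0.48 log units; beyond the scatter). Measurable inhibition therefore does not require isopropylsulfonyl at this place. The step has an open end, resting on a limit of the assay: the limit of > 4000 nM in this assay, at which 2 of the 3 values shown sit.

As far as these compounds go, it remains open whether the fluorine or the loss of isopropylsulfonyl carries the step. An unfluorinated propyl chain or an amine at this place would help separate the two.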